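This account rests on a few compounds, and the source may have more. Where it says the series, first, only, none or still open, it means among the compounds named here.

Measured compounds:
compound 1, `O=C1CSC(c2c(Cl)cccc2Cl)N1CCN1CCCCC1`, 100%
compound 2, `O=C1CSC(c2ccc(F)cc2)N1CCN1CCCCC1`, 100%
compound 3, `O=C1CSC(c2cccc(F)c2)N1CCN1CCCCC1`, 97%

All three were tested in an ADME assay on Vero cells (Chlorocebus sabaeus) for cytotoxicity, read by neutral red uptake, tested at 49 ug/mL; on this read-out higher numbers stand for a weaker effect at the one concentration tested and lower numbers for a stronger effect. Compound 1 gives 100%, compound 2 gives 100% and compound 3 gives 97%, so the three numbers lie within the usual scatter of one another and compound 3 cannot be told apart from compound 1 or compound 2 on these values.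

Compound 4, `O=C1CSC(c2ccccc2Cl)N1CCN1CCCCC1`, has not yet been measured. It differs from compound 3 in one place: 2-chlorophenyl in place of 3-fluorophenyl on a saturated ring carbon.

Going by the values given here, one measured step bears on this change. From compound 2 to compound 3 the fluorine moved on the phenyl ring, and a number 3 percentage points lower from compound 2 to compound 3 (within the scatter). Compound 1, which carries two chlorines on its phenyl ring, shows a value in this assay that matches compound 3 within the scatter. Every change to the phenyl ring seen so far has left the read-out unchanged within the scatter, and a chlorine on that ring appears in compound 1 without lowering it.

The step from compound 3 to compound 4 is therefore expected to be a number 2 percentage points higher from compound 3 to compound 4 (within the scatter), no larger than the scatter. Compound 4 is estimated to give 99%, with a range from 90% to 100%.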

Compound 4, a percentage reported as activity, at one concentration (the size of the read-out at that concentration, not a potency): 100%
Estimate against measurement, compound 4: 1 percentage points below; the range from low to high includes it.
By their numbers in this assay, from the lowest: compounds 3, 1, 2 and 4 (each within the scatter of the next).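

Taking away one chlorine from the ring of compound 1 is a single clean change: in this assay the result is no change at the digits printed from compound 1 to compound 4 (within the scatter) when hydrogen takes the place of chloro on an aromatic carbon, so one chlorine and two chlorines on this phenyl ring cannot be told apart here. Exchanging the fluorine for a chlorine while also changing where the halogen sits gives a number 3 percentage points higher from compound 3 to compound 4 (within the scatter) and, starting from the 4-fluorophenyl group, no change at the digits printed from compound 2 to compound 4 (within the scatter) on the same saturated ring carbon, which places 2-chlorophenyl alongside 3-fluorophenyl and 4-fluorophenyl as groups that this read-out does not separate. No further measurement is available to say what lies behind this sameness.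

Every ring substituent shown so far is a halogen, so it remains open whether an amine, a carboxylic acid or a methoxy group on the phenyl ring, or a plain unsubstituted phenyl, would give the same picture. Also open, on these data alone, is what a longer chain on the ring nitrogen would do, and whether these compounds would stay alike at another concentration.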